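A few compounds are considered here, and "the series" means these few. Any claim that something is new, unique, unknown or untested is made for them only; others in the source may bear on it.

In a functional assay on HOP-62 cells (Homo sapiens) for inhibition, read by sulforhodamine B assay (a lower number here means a stronger inhibitor of growth, a higher number a weaker inhibitor of growth), compound 1 (`FC(F)(F)Oc1ccc(-c2ccc(-c3ccc(-c4nc5ccccc5[nH]4)cc3)cc2)cc1`) gives 100000 nM. Compound 2 (`Cc1ccc2[nH]c(-c3ccc(-c4ccc(-c5ccccc5)cc4)cc3)nc2c1`) gives 39300 nM, and compound 3 (`Cc1ccc2[nH]c(-c3ccc(-c4ccc(-c5ccc(F)cc5)cc4)cc3)nc2c1`) gives 33500 nM. Compound 3 therefore stands level with compound 2 within the scatter, while the number of compound 1 is higher than both, by a gap beyond the scatter from compound 3.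

Compound 4 (`Cc1ccc2[nH]c(-c3ccc(-c4ccc(-c5ccc(OC(F)(F)F)cc5)cc4)cc3)nc2c1`) follows from compound 3 by a single change: trifluoromethoxy in place of fluoro on an aromatic carbon. Trifluoromethoxy takes the place of fluoro on an aromatic carbon, para to a large group.

Within the data shown here, only one measured step bears directly on this place, namely a 1.2-fold lower number from compound 2 to compound 3 (0.07 log units; within the scatter), where fluoro replaced hydrogen on an aromatic carbon. That step says nothing direct about trifluoromethoxy. Among the measured compounds shown here, compound 1, the only measured compound with that group, gives 100000 nM, which hints at a weaker result, but it differs from compound 4 elsewhere as well, and no measured pair isolates the group. A small upward drift is therefore expected at most, and the expected step is a 1.3-fold higher number from compound 3 to compound 4 (0.13 log units; within the scatter), which stays within the scatter. For compound 4 the estimated value is 45000 nM, with an expected range from 20000 nM to 100000 nM.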

Compound 4, concentration for 50% growth inhibition: 24200 nM
The estimate for compound 4 lay 1.9-fold (0.27 log units) above the measured number; low and high end bracket the measured number.
By their numbers in this assay, from the lowest: compounds 4, 3 and 2 (each within the scatter of the next); then compound 1.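

In this assay, trifluoromethoxy in place of fluoro (a 1.4-fold lower number from compound 3 to compound 4 (0.14 log units; within the scatter)) and trifluoromethoxy in place of hydrogen (a 1.6-fold lower number from compound 2 to compound 4 (0.21 log units; within the scatter)) both stay within the scatter, so this place on the aromatic carbon, para to a large group, now holds a group of several heavy atoms with no change that the data can resolve. Among these compounds, the hint taken from compound 1 therefore falls away: with trifluoromethoxy present in both compounds, the gap between compound 1 and compound 4 belongs to the other place, where compound 4 carries a methyl that compound 1 lacks (a 4.1-fold lower number from compound 1 to compound 4 (0.62 log units; beyond the scatter)), the only one of these steps beyond the scatter, and a modest one. Nothing on hand gives a reason for either reading.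

From the compounds shown here alone, whether an amine or a carboxylic acid, or a longer chain, at this same place would move the number beyond the scatter remains open. Going by these compounds, the methyl step also rests on this single pair, so it is open whether it would recur with hydrogen or fluoro at the far end of the molecule.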